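The source may report more compounds than this note shows. Statements on the series, on what has been measured and on what is new or still open speak of the compounds shown alone.

In an ADME assay on BEAS-2B cells (Homo sapiens) for cytotoxicity, read by MTT assay, with a stated time of 72 h (on this read-out lower numbers stand for stronger inhibition of growth and higher numbers for weaker inhibition of growth), compound 1 `CCCOC(=O)Nc1ccc([Se]C#N)cc1` gives 46300 nM. Among the three measured compounds it stands second highest, though its neighbours lie within the scatter on either side: compound 2 `CCCCOC(=O)Nc1ccc([Se][Se]c2ccc(NC(=O)OCCCC)cc2)cc1` gives 49600 nM in this assay, and compound 3 `C=CCOC(=O)Nc1ccc([Se][Se]c2ccc(NC(=O)OCC=C)cc2)cc1` gives 42900 nM. Within the data shown here, since all three values lie within the scatter of one another, no order among them can be read, and none of the pairs differs in a single place, so no measured step is available.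

Compound 4 `CCCCCCOC(=O)Nc1ccc([Se]C#N)cc1` is the next compound to be measured in this assay. It differs from compound 1 as follows: propyl in place of hydrogen on a saturated chain carbon, three bonds along the chain from an oxygen next to a carbonyl group.

Nothing in the measured set speaks to a change of this kind, since the carbamate chains of compound 2 and compound 3 are carried on different cores. The three values cluster closely, so the step in this assay from compound 1 to compound 4 is expected to be small, in either direction or none beyond the scatter, at a 1.0-fold lower number from compound 1 to compound 4 (0.01 log units; within the scatter). Compound 4 is therefore estimated to give about 45000 nM in this assay, in a range from 20000 nM to 100000 nM.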

Compound 4, concentration for total growth inhibition: 35900 nM
Estimate against measurement, compound 4: 1.3-fold (0.10 log units) above; the range from low to high includes it.
By their numbers in this assay, from the lowest: compounds 4, 3, 1 and 2 (each within the scatter of the next).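

In this assay, replacing hydrogen with propyl on a saturated chain carbon, three bonds along the chain from an oxygen next to a carbonyl group, comes to a 1.3-fold lower number from compound 1 to compound 4 (0.11 log units; within the scatter). Among these compounds, this is the first single-place comparison in the set, and it shows that going from propyl to hexyl on the core of compound 1 produces no change beyond the scatter. No independent measurement bears on this result.

The compounds shown leave open whether a longer chain than hexyl, or a chain ending in an amine or a carboxylic acid, would move the number beyond the scatter at this place. They also leave open whether the same change would behave alike on the cores of compound 2 and compound 3.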